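Sulfonamide series: tert-butyl added to compound 2

A few compounds are considered here, and "the series" means these few. Any claim that something is new, unique, unknown or untested is made for them only; others in the source may bear on it.

Values in a functional assay on MGC-803 cells (Homo sapiens) for inhibition, read by MTT assay, with a stated time of 48 h; a higher number here means a weaker inhibitor, a lower number a stronger inhibitor:
- Compound 1 `COc1ccc(CN(c2cc(OC)c(OC)c(OC)c2)S(=O)(=O)c2ccccc2)cc1`: > 50000 nM, a limit
- Compound 2 `COc1cc(N(Cc2nc3ccccc3[nH]2)S(=O)(=O)c2ccccc2)cc(OC)c1OC`: 12400 nM
- Compound 3 `COc1cc(N(Cc2nc3ccccc3[nH]2)S(=O)(=O)c2ccc(C(C)(C)C)cc2)cc(OC)c1OC`: not yet measured

Within the data shown here, compound 2 holds the only true number in this assay so far. Compound 3 differs from it by tert-butyl in place of hydrogen on an aromatic carbon. Among the measured compounds shown here, the one measured step, an at least 4.0-fold lower number from compound 1 to compound 2 (0.60 log units; beyond the scatter), lies at another place on the molecule and gives no direct guide to this change. For the measured compounds named here, with no measured step at this place, only a modest, uncertain shift towards a lower number is expected. The expected step is a 1.8-fold lower number from compound 2 to compound 3 (0.25 log units; within the scatter). For compound 3 the estimated value is 7000 nM, with an expected range of 1800 nM to 30000 nM.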

Compound 3, half-maximal inhibitory concentration: 24100 nM
Estimate against measurement, compound 3: 3.4-fold (0.54 log units) below; the measured number falls inside the stated range.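

Phenyl to 4-(tert-butyl)phenyl is the only change read at this place, and in this assay it gives a 1.9-fold higher number from compound 2 to compound 3 (0.29 log units; within the scatter). The place therefore accepts tert-butyl without a shift beyond the scatter, and this group brings no gain in potency. Compound 1 remains a limit and not a number, so the series offers only one exact step at another place: the limit of > 50000 nM in this assay, at which 1 of the 3 values shown sits.

On these data alone, whether an amine or a carboxylic acid at this place would move the number stays open. The compounds shown also leave open whether a methoxy group there would behave like tert-butyl.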